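Cyclopropyl for ethyl on the amide-bearing chain carbon

The compounds below may be only part of what the source reports. "The series", "measured", "known", "first", "only" and "open" are said of these compounds alone.

Compound 1 `CC[C@H](CCCc1cccnc1)NC(=O)/C=C/C=C(c1ccc(OC)cc1)c1ccc(OC)cc1` is tested in an assay (Canis lupus familiaris) for binding affinity to platelet-activating factor receptor (Homo sapiens), read by radioligand binding (a lower number here means a stronger inhibitor, a higher number a weaker inhibitor), and gives 120 nM, the highest of the three numbers recorded so far. Compound 3 `O=C(C/C=C/C=C(c1ccccc1)c1ccccc1)NCCCCc1cccnc1` gives 55 nM in this assay, and compound 2 `COc1ccc(/C=C/C=C/C(=O)N[C@H](C)CCCc2cccnc2)cc1` gives 30 nM; both gaps to compound 1 lie beyond the usual scatter. Compound 4 `COc1ccc(C(=C/C=C/C(=O)N[C@@H](CCCc2cccnc2)C2CC2)c2ccc(OC)cc2)cc1` is not yet measured. It differs from compound 1 in one place: cyclopropyl in place of ethyl on a saturated chain carbon bound to an amide-type nitrogen and a saturated chain carbon. Within the data shown here, no measured pair in this set shows the same change, so nothing here fixes its size. The step expected is a 1.2-fold lower number from compound 1 to compound 4 (0.08 log units; within the scatter), modest, and as likely to fall within the scatter as beyond it in either direction. For compound 4 the estimate in this assay is 100 nM, with a range of 40 nM to 300 nM.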

Compound 4, half-maximal inhibitory concentration: 60 nM
Estimate against measurement, compound 4: 1.7-fold (0.22 log units) above, and the stated range covers the measured number.
By their numbers in this assay, from the lowest: compounds 2, 3, 4 and 1 (each within the scatter of the next, the first and the last beyond it).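

In this assay, among these compounds, cyclopropyl in place of ethyl on a saturated chain carbon bound to an amide-type nitrogen and a saturated chain carbon gives a 2.0-fold lower number from compound 1 to compound 4 (0.30 log units; within the scatter) and is the first reading of this change. The position therefore takes a three-membered ring and one more carbon, with compound 1 and compound 4 not resolved from each other. Nothing available bears on the reason for this result.

Open, as far as these compounds go, is whether cyclobutyl, isopropyl or a longer chain on this carbon would read differently on the core of compound 1. Also open, from the compounds shown here alone, is whether the same change would give a similar step on another core.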